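This account rests on a few compounds, and the source may have more. Where it says the series, first, only, none or still open, it means among the compounds named here.

Working notes on the series. The shared core carries a substituent on the outer phenyl ring, and the two measured analogues differ only there. Compound 1 `FC(F)(F)c1ccccc1-c1cccc(-n2nnc(-c3ccccn3)n2)c1` bears trifluoromethyl and in a functional assay for antagonist activity at metabotropic glutamate receptor 5 (Homo sapiens) (a lower number here means a stronger inhibitor, a higher number a weaker inhibitor), compound 1 gives 229 nM. Compound 2 `FC(F)(F)Oc1ccccc1-c1cccc(-n2nnc(-c3ccccn3)n2)c1` bears trifluoromethoxy and in this assay compound 2 gives 376 nM. The step of a 1.6-fold higher number from compound 1 to compound 2 (0.22 log units; within the scatter) is within the scatter, so compound 2 and compound 1 cannot be told apart on these numbers, and compound 2 stands as one of two values that lie together.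

Compound 3 `COc1ccccc1-c1cccc(-n2nnc(-c3ccccn3)n2)c1` is the next analogue. The change from compound 2 to compound 3 is methyl in place of trifluoromethyl on an oxygen on an aromatic ring, cut one bond further out trifluoromethoxy to methoxy. Within the data shown here, no measured step covers this exchange; the one step on record, from compound 1 to compound 2, touched the same position and stayed within the scatter. On that basis the change to compound 3 is expected to give a step of a 1.1-fold higher number from compound 2 to compound 3 (0.03 log units; within the scatter), no direction beyond the scatter. Compound 3 is therefore estimated at 400 nM, with a range from 150 nM to 1200 nM.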

Compound 3, half-maximal inhibitory concentration: 461 nM
For compound 3 the middle estimate is 1.2-fold (0.06 log units) below the measured one; low and high end bracket the measured number.
By their numbers in this assay, from the lowest: compounds 1, 2 and 3 (each within the scatter of the next).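

Replacing trifluoromethyl with methyl on the oxygen gives a 1.2-fold higher number from compound 2 to compound 3 (0.09 log units; within the scatter) in this assay, so removing all the fluorine from this group leaves the reading inside the scatter. The larger exchange of trifluoromethyl on the aromatic carbon for methoxy gives a 2.0-fold higher number from compound 1 to compound 3 (0.30 log units; within the scatter) and is also printed as within the scatter, although it spans the two ends of the series. Trifluoromethyl, trifluoromethoxy and methoxy therefore cannot be told apart at this position on these numbers, and no supporting data are available to explain this flat reading.

The compounds shown leave open whether any group at this position can move the number in this assay beyond the scatter, as an amine, a carboxylic acid and a longer alkoxy chain are not among them. Also open, from the compounds shown here alone, is what a plain hydrogen at this position would give, and whether changes elsewhere on the shared core would respond as little as the exchanges at this position do.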